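Working notes: from compound 2 to compound 4

The compounds below may be only part of what the source reports. "The series", "measured", "known", "first", "only" and "open" are said of these compounds alone.

- compound 1 `O=S(=O)(NCCN1CCCC1)c1cccc(-c2ccc3nccc(-c4ccnc(C(F)(F)F)c4)c3n2)c1` at 145000 nM (a number)
- compound 2 `O=S(=O)(c1cccc(Nc2ccc3nccc(-c4ccncc4)c3n2)c1)N1CCCC1` at < 5000 nM (a limit)
- compound 3 `CS(=O)(=O)c1cccc(-c2ccc3nccc(-c4ccncc4)c3n2)c1` at < 5000 nM (a limit)

In a physicochemical assay for solubility, read by HPLC, using the shake flask method, measured as kinetic solubility, with a stated time of 20 h, at pH 6.5, tested at 200 uM (on this read-out lower numbers stand for lower solubility and higher numbers for higher solubility), compound 2 gives < 5000 nM (a limit of the assay and not a number). Compound 3 gives < 5000 nM (also a limit). Compound 2 therefore stands at the limit of < 5000 nM in this assay, at which 2 of the 3 values shown sit (no number is available for it). Among the measured compounds shown here, compound 1 reads 145000 nM as the only number in the set.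

For the measured compounds named here, compound 4 `NCCNS(=O)(=O)c1cccc(Nc2ccc3nccc(-c4ccncc4)c3n2)c1` has (2-aminoethyl)amino in place of the pyrrolidin-1-yl of compound 2 on a sulfonyl sulfur, a change counted as (2-aminoethyl)amino in place of pyrrolidin-1-yl on a sulfonyl sulfur (with no measured counterpart in the set). A rise in this assay is expected, with an estimated at least 8.0-fold higher number from compound 2 to compound 4 (0.90 log units; beyond the scatter) as its size. The expectation rests on compound 1 at 145000 nM (which also has an open chain on the sulfonyl sulfur). A reading at the limit remains possible for compound 4. Compound 4 is estimated at 40000 nM (expected range 5000 nM to 180000 nM) in this series.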

Compound 4, solubility: 200000 nM
Compound 4: middle estimate off by 5.0-fold (0.70 log units), on the low side; the whole stated range lies below it.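

In this assay the sulfonyl sulfur proves to be a place where a single change carries a large step: an at least 40-fold higher number from compound 2 to compound 4 (1.60 log units; beyond the scatter) comes with (2-aminoethyl)amino in place of pyrrolidin-1-yl. Among the compounds shown here, compounds 1, 2 and 3 differ from one another in more than one place, so compound 4 supplies the first step in the set that can be read at this position. The reading for compound 2 is a limit and not a number, so the step has a known floor but no known size: the limit of < 5000 nM in this assay, at which 2 of the 4 values shown sit.

On these data alone, it remains open whether the gain follows the primary amine of the new chain or the open chain itself. A longer chain, a dimethylamino group at the chain end or a carboxylic acid in place of the amine would separate these readings.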